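The compounds below may be only part of what the source reports. "The series", "measured", "known", "first", "only" and "open" are said of these compounds alone.

Measured in an assay on HEK293 cells for positive allosteric modulation of metabotropic glutamate receptor 2 (Rattus norvegicus), read by thallium flux, with a stated time of 2.5 min (on this read-out lower numbers stand for smaller maximal responses and higher numbers for larger maximal responses), so far:
- compound 1, `Cc1c(OCCCCOc2ccc(C(=O)O)cc2)ccc(C(=O)CC2CCCC2)c1O`: 82.6%
- compound 2, `Cc1c(OCCCCOc2ccc(C(=O)O)cc2)ccc(C(=O)CC(C)C)c1C`: 19%
- compound 3, `Cc1c(OCCCCOc2cccc(C(=O)O)c2)ccc(C(=O)CC2CCCC2)c1O`: 80.6%

Compound 1 and compound 3 share one core and differ only by 3-carboxyphenyl in place of 4-carboxyphenyl on an oxygen on a saturated carbon. In this assay that change gives a number 2 percentage points lower from compound 1 to compound 3 (within the scatter), so the largest response reached is left essentially unchanged by moving the carboxyl from one ring position to the other.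

Compound 2 carries a different core; the difference between the cores of compound 1 and compound 2 is not broken down here. In this assay compound 2 stands lowest of the three, and its gaps to compound 3 and to compound 1 both lie beyond the usual scatter.

Compound 4, `Cc1c(OCCCCOc2cccc(C(=O)O)c2)ccc(C(=O)CC(C)C)c1C`, has not been measured. It differs from compound 2 by 3-carboxyphenyl in place of 4-carboxyphenyl on an oxygen on a saturated carbon, the same change, at the same kind of place, as from compound 1 to compound 3. From compound 2 to compound 4 a step of a number 1 percentage points lower from compound 2 to compound 4 (within the scatter) in this assay is expected, because the matched pair gave only a number 2 percentage points lower from compound 1 to compound 3 (within the scatter). Compound 4 is therefore estimated at 18%, with a plausible range from 6% to 34%.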

Compound 4, largest response reached (reported as percent of maximum), in percent of the reference or control that the assay uses: 12.1%
Compound 4: middle estimate off by 5.9 percentage points, on the high side, within the range that was stated.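

Working from this assay, the change to 3-carboxyphenyl in place of 4-carboxyphenyl on an oxygen on a saturated carbon gives a number 6.9 percentage points lower from compound 2 to compound 4 (within the scatter), so on this second core the largest response reached again shows no change beyond the usual scatter. Set beside the earlier step, the change carries over from one core to the other with no detectable difference: the same change on two cores in this assay, a number 2 percentage points lower (within the scatter) from compound 1 to compound 3 and a number 6.9 percentage points lower (within the scatter) from compound 2 to compound 4, 4.9 percentage points apart, within the scatter of two such steps

Going by these compounds alone, this agreement rests on only two cores and does not show that the step would stay this small on any other core. With both steps inside the scatter, a small real effect of the change cannot be told from none, and the data give no reason for the result.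

Still open, as far as these compounds go, is whether the step stays this small when a primary amide or a tetrazole replaces the carboxylic acid. From the compounds shown here alone, a longer saturated chain on that oxygen is equally open.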